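The compounds below may be only part of what the source reports. "The series", "measured", "known", "first", "only" and "open" are said of these compounds alone.

Compound 2, `CCCCCCCCNC(=O)[C@@H](NC(=O)c1nccc2ccccc12)[C@@H](C)O`, is one of three amides of the same threonine-derived core examined here. In a functional assay on A-431 cells (Homo sapiens) for cytotoxicity, read by MTT assay, with a stated time of 48 h (on this read-out lower numbers stand for stronger inhibition and higher numbers for weaker inhibition), compound 2 gives 26900 nM. The other two bear different groups at the two ends of that core: compound 1, `CCCCCCCCCCCCCCCCCCNC(=O)[C@@H](N)[C@@H](C)O`, gives 21300 nM in this assay, and compound 3, `CCCCCCCCNC(=O)[C@@H](NC(=O)/C=C/c1ccccc1)[C@@H](C)O`, gives 36000 nM. The value of compound 2 sits within the scatter of both neighbours, so the three numbers cannot be told apart on this read-out, and no ordering among them is claimed.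

Compound 4, `CCCCCCCCCCCCNC(=O)[C@@H](NC(=O)c1nccc2ccccc12)[C@@H](C)O`, is the not yet measured partner of compound 2. The change between them is butyl in place of hydrogen on a saturated chain carbon, eight bonds along the chain from an amide-type nitrogen. Among the compounds with values here, no measured pair in this set isolates a lengthening of that chain, and the widely different compound 1 carries a much longer chain without giving a clearly different number, so a step in this assay from compound 2 to compound 4 of a 1.7-fold lower number from compound 2 to compound 4 (0.23 log units; within the scatter) is expected, lying within the scatter or only slightly beyond it toward lower numbers. For compound 4 the expected value in this assay is therefore 16000 nM, with a range from 5000 nM to 45000 nM.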

Compound 4, half-maximal inhibitory concentration: 62800 nM
Estimate against measurement, compound 4: 3.9-fold (0.59 log units) below, and the stated range ends below it.
By their numbers in this assay, from the lowest: compounds 1, 2, 3 and 4 (each within the scatter of the next, the first and the last beyond it).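

Butyl in place of hydrogen on a saturated chain carbon, eight bonds along the chain from an amide-type nitrogen, is the first change in this set that can be read on its own, and in this assay it gives a 2.3-fold higher number from compound 2 to compound 4 (0.37 log units; beyond the scatter). At this position, then, the added carbons move the number beyond the scatter, and they move it toward weaker inhibition, although the step is modest. Nothing shown here explains this step.

On these data alone, a single step traces no trend along the chain, so it stays open whether a hexyl chain or a longer chain in this place, or an amine or a carboxylic acid carried on the chain, would move the number. As far as these compounds go, it is equally open whether the same butyl change would act alike on compound 3.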